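The compounds below may be only part of what the source reports. "The series", "measured", "known", "first", "only" and "open" are said of these compounds alone.

Of the compounds shown here, three have numbers so far. Compound 1 `CN1CCN(CCC(=O)N2CCC3(N4CCN(C)CC4)CC(c4ccccc4)C2C(c2ccccc2)C3)CC1` gives 161000 nM in an ADME assay on L6 cells (Rattus norvegicus) for cytotoxicity; on this read-out higher numbers stand for weaker inhibition and lower numbers for stronger inhibition; compound 2 `CN1CCN(CCCC(=O)OC2CC3(N(C)C)CC(c4ccccc4)C2C(c2ccccc2)C3)CC1` gives 19900 nM in this assay; compound 3 `CN1CCN(CCCN2CCC3(N4CCCCC4)CC(c4ccccc4)C2C(c2ccccc2)C3)CC1` gives 62500 nM. Compound 3 thus stands second highest of the three: compound 1 shows a higher number and compound 2 a lower one, both gaps beyond the scatter. Compound 4 `CN1CCN(CCCN2CCC3(N4CCCC4)CC(c4ccccc4)C2C(c2ccccc2)C3)CC1` is not yet measured. It differs from compound 3 in one place: pyrrolidin-1-yl in place of piperidin-1-yl on a saturated ring carbon. Among the measured compounds shown here, no measured pair differs in a single place, so no measured step anchors the expectation; the change is small, and a step within the scatter, in no firm direction, is expected. For compound 4 the expected step is a 1.0-fold lower number from compound 3 to compound 4 (0.02 log units; within the scatter), giving an estimated value of 60000 nM, with a range from 25000 nM to 150000 nM.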

Compound 4, half-maximal inhibitory concentration: 27500 nM
The estimate for compound 4 lay 2.2-fold (0.34 log units) above the measured number; low and high end bracket the measured number.
By their numbers in this assay, from the lowest: compounds 2 and 4 (each within the scatter of the next); then compound 3; then compound 1.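

In this assay, among the compounds shown here, the exchange of piperidin-1-yl for pyrrolidin-1-yl on this saturated ring carbon gives a 2.3-fold lower number from compound 3 to compound 4 (0.36 log units; beyond the scatter) and is the first single-place step. The number at this position thus responds to the size of the amine ring, though the step is modest. Nothing at hand accounts for the step.

From the compounds shown here alone, one step gives no trend, so the effect of azepan-1-yl or morpholin-4-yl at this carbon stays open. Going by these compounds, whether the same exchange gives a similar step with another side chain on the ring nitrogen also stays open.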